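Azole exchange on the carbonyl carbon of the ketone series

The source may report more compounds than this note shows. Statements on the series, on what has been measured and on what is new or still open speak of the compounds shown alone.

Compound 2 `O=C(CCCCCCc1ccccc1)c1ncon1` gives 500 nM in an assay for inhibition of Fatty-acid amide hydrolase 1 (Rattus norvegicus) (a lower number here means a stronger inhibitor, a higher number a weaker inhibitor), the highest number of the three measured; compound 1 `O=C(CCCCCCc1ccccc1)c1ncno1` gives 4 nM and compound 3 `O=C(CCCCCCc1ccccc1)c1noc(-c2ccccn2)n1` gives 7 nM. Compound 4 `O=C(CCCCCCc1ccccc1)c1nncs1` carries 1,3,4-thiadiazol-2-yl in place of 1,2,4-oxadiazol-3-yl on a carbonyl carbon. The step that bears on this is the earlier ring exchange on the same carbonyl carbon, a 130-fold higher number from compound 1 to compound 2 (2.10 log units; beyond the scatter), a large loss; the substituent step a 71-fold lower number from compound 2 to compound 3 (1.85 log units; beyond the scatter) shows that from compound 2 a large gain is reachable. Both measured steps lie far beyond the scatter, so a large step is expected here too, more likely downward, back toward compound 1, though its direction rests on one ring swap only. Compound 4 is expected at 40 nM, in the range 5 nM to 400 nM, a step of a 13-fold lower number from compound 2 to compound 4 (1.10 log units; beyond the scatter).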

Compound 4, half-maximal inhibitory concentration: 300 nM
Beside the measured number, compound 4's estimate is 7.5-fold (0.88 log units) below it; low and high end bracket the measured number.
By their numbers in this assay, from the lowest: compounds 1 and 3 (each within the scatter of the next); then compounds 4 and 2 (each within the scatter of the next).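

On the carbonyl carbon, 1,3,4-thiadiazol-2-yl and 1,2,4-oxadiazol-3-yl are not told apart in this assay (a 1.7-fold lower number from compound 2 to compound 4 (0.22 log units; within the scatter)). The large gap from the ring of compound 1 now holds for a second ring (a 75-fold higher number from compound 1 to compound 4 (1.88 log units; beyond the scatter)), so among these three rings without a further substituent, only 1,2,4-oxadiazol-5-yl stands apart. Nothing available accounts for this difference between the rings.

Open, from the compounds shown here alone, is whether pyridin-2-yl on the 1,3,4-thiadiazol-2-yl ring of compound 4 would bring a gain like that seen with compound 3. Also open, going by these compounds, is how a carboxylic acid or an amine at that ring carbon would read.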